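The source may report more compounds than this note shows. Statements on the series, on what has been measured and on what is new or still open speak of the compounds shown alone.

Among the measured compounds shown here, in a functional assay on MOLT-4 cells (Homo sapiens) for inhibition (on this read-out lower numbers stand for stronger inhibition of growth and higher numbers for weaker inhibition of growth), compound 2 `C=C1C(=O)O[C@H]2[C@H]1CC/C(COC(=O)NCCN1CCCC1)=C\CC[C@@]1(C)O[C@@H]21` gives 3480 nM and compound 1 `C=C1C(=O)O[C@H]2[C@H]1CC/C(COC(=O)N1CCC(F)(F)CC1)=C\CC[C@@]1(C)O[C@@H]21` gives 2050 nM on the same read-out, so compound 2 cannot be told apart from the only other measured compound. Compound 3 `C=C1C(=O)O[C@H]2[C@H]1CC/C(COC(=O)Nc1n[nH]c(SC)n1)=C\CC[C@@]1(C)O[C@@H]21` differs from compound 2 by 5-(methylsulfanyl)-1H-1,2,4-triazol-3-yl in place of 2-(pyrrolidin-1-yl)ethyl on an amide-type nitrogen and nothing else changes. For the measured compounds named here, the one measured step that bears on this is a 1.7-fold higher number from compound 1 to compound 2 (0.23 log units; within the scatter) and it also exchanges the group on the carbonyl carbon. No step beyond the scatter is therefore expected, and the estimated step is a 1.7-fold lower number from compound 2 to compound 3 (0.24 log units; within the scatter) in this assay here. For compound 3 the estimated value is 2000 nM within an expected range of 500 nM to 6000 nM on this read-out.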

Compound 3, concentration for 50% growth inhibition: 2320 nM
For compound 3 the middle estimate is 1.2-fold (0.06 log units) below the measured one; measured number inside the range.
By their numbers in this assay, from the lowest: compounds 1, 3 and 2 (each within the scatter of the next).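

In this assay, replacing the non-aromatic 2-(pyrrolidin-1-yl)ethyl with the aromatic 5-(methylsulfanyl)-1H-1,2,4-triazol-3-yl on the amide-type nitrogen gives a 1.5-fold lower number from compound 2 to compound 3 (0.18 log units; within the scatter). Exchanging the 4,4-difluoropiperidin-1-yl on the carbonyl carbon for (5-(methylsulfanyl)-1H-1,2,4-triazol-3-yl)amino gives a 1.1-fold higher number from compound 1 to compound 3 (0.05 log units; within the scatter), so three different groups at this position now leave the read-out within the scatter. No available evidence accounts for this result.

From the compounds shown here alone, it remains open whether a carboxylic acid, a primary amine or a longer alkyl chain on the amide-type nitrogen would produce a step beyond the scatter.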